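Fluoro in place of hydrogen across two cores

The source may report more compounds than this note shows. Statements on the series, on what has been measured and on what is new or still open speak of the compounds shown alone.

Compound 1 `COc1ccc([C@@H]2c3c(OC)cc(OC)cc3/C(=C/c3ccccc3)[C@H]2c2cc(OC)cc(OC)c2)cc1` and compound 2 `COc1ccc([C@@H]2c3c(OC)cc(OC)cc3/C(=C/c3ccc(F)cc3)[C@H]2c2cc(OC)cc(OC)c2)cc1` share one core; compound 3 `COc1cc(OC)cc([C@@H]2C(O)c3cc(OC)cc(OC)c3[C@H]2c2ccccc2)c1` and compound 4 `COc1cc(OC)cc([C@@H]2C(O)c3cc(OC)cc(OC)c3[C@H]2c2ccc(F)cc2)c1` share another, and the difference between the two cores is not broken down here. In a functional assay on RAW264.7 cells (Mus musculus) for inhibition, with stated times of 2 h and 24 h (a lower number here means a stronger inhibitor, a higher number a weaker inhibitor), compound 1 returns only a limit, > 200000 nM. Compound 2 likewise returns a limit in this assay, > 200000 nM. The change between them is fluoro in place of hydrogen on an aromatic carbon, and the step that the two limits leave unreadable from compound 1 to compound 2 cannot be sized because of the limit of > 200000 nM in this assay, at which 2 of the 3 values shown sit. For the measured compounds named here, compound 3 is the one member with a number: in this assay compound 3 gives 3380 nM. Compound 4 carries the same change, (fluoro in place of hydrogen on an aromatic carbon); the surroundings of the place read alike in both pairs, so this is the same change, not merely the same kind. No measured pair sizes this change. The expectation for compound 4 therefore rests on compound 3 alone, whose value 3380 nM is the only anchor. The step is expected to be small: a 1.1-fold lower number from compound 3 to compound 4 (0.05 log units; within the scatter). Compound 4 is estimated at 3000 nM in this assay, within a range from 1200 nM to 9000 nM.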

Compound 4, half-maximal inhibitory concentration: "not active" (no number reported)
No number was reported for compound 4, and the estimate cannot be compared.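

For the compounds shown here, no step from compound 3 to compound 4 can be read: in this assay compound 3 gives 3380 nM, while compound 4 is reported as "not active" with no number. The compounds shown leave open what size, if any, the change from phenyl to 4-fluorophenyl has in either core, and how the reading for compound 4 relates to the limit: the limit of > 200000 nM in this assay, at which 2 of the 4 values shown sit.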